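The source may hold more compounds than are shown below. What is called first, only, known or untested is meant among the compounds shown, and "the series" means these compounds.

In a functional assay on SMMC-7721 cells (Homo sapiens) for antiproliferative activity, read by MTT assay, with a stated time of 72 h (on this read-out higher numbers stand for weaker inhibition and lower numbers for stronger inhibition), three compounds of one series have numbers. Compound 1 `Cc1nn(C)c(Oc2cccc(F)c2)c1/C=N\CCCCCOc1cc2oc(=O)cc(C)c2cc1Cl` gives 11800 nM. Compound 2 `Cc1nn(C)c(Oc2ccc(I)cc2)c1/C=N\CCCCCOc1cc2oc(=O)cc(C)c2cc1Cl` reaches only a limit of the assay, > 25000 nM. Compound 3 `Cc1nn(C)c(Oc2cccc(F)c2)c1/C=N\CCCCCCOc1cc2oc(=O)cc(C)c2cc1Cl` gives 23600 nM, the higher of the two plain numbers, with compound 1 nearest at a gap that stays within the scatter.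

Within the data shown here, the one measured step that swaps the aryl group on the oxygen is an at least 2.1-fold higher number from compound 1 to compound 2 (0.32 log units; beyond the scatter); its size cannot be fixed more closely because of the limit of > 25000 nM in this assay, at which 1 of the 3 values shown sits.

Compound 4 `Cc1nn(C)c(Oc2ccc(Cl)cc2)c1/C=N\CCCCCCOc1cc2oc(=O)cc(C)c2cc1Cl` has not been measured. It differs from compound 3 by 4-chlorophenyl in place of 3-fluorophenyl on an oxygen on an aromatic ring. Among the measured compounds shown here, this change runs parallel to the step from compound 1 to compound 2, in that both replace 3-fluorophenyl with a phenyl carrying a heavier halogen, so a weakening of similar size is the natural expectation, with the caveat that only one such step exists and its full extent is unknown. Compound 4 is therefore expected to show a 1.7-fold higher number from compound 3 to compound 4 (0.23 log units; within the scatter). The estimate for compound 4 in this assay is 40000 nM, within 18000 nM to 90000 nM, with a real chance that only a limit is reported.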

Compound 4, half-maximal inhibitory concentration: 2080 nM
For compound 4 the middle estimate is 19-fold (1.28 log units) above the measured one, outside the stated range (below it).
By their numbers in this assay, from the lowest: compound 4; then compounds 1 and 3 (each within the scatter of the next). At a limit, above all of these: compound 2.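

In this assay, among these compounds, the aryl group on the oxygen turns out to be able to shift the number strongly towards stronger inhibition, which the earlier compounds did not show: the new step is an 11-fold lower number from compound 3 to compound 4 (1.05 log units; beyond the scatter). Among the compounds shown here, the one earlier step at this place ran the other way, an at least 2.1-fold higher number from compound 1 to compound 2 (0.32 log units; beyond the scatter), so across these two pairs, which carry different entering groups and different chains, leaving 3-fluorophenyl has no single direction. The size of that earlier step stays loose: the limit of > 25000 nM in this assay, at which 1 of the 4 values shown sits.

From the compounds shown here alone, it remains open whether 4-chlorophenyl brings the same gain on the shorter chain of compound 1 or only on the longer chain of compound 3. Going by these compounds, how an unsubstituted phenyl or a 4-methoxyphenyl group would read at this place also remains open.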